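The source may hold more compounds than are shown below. What is called first, only, known or untested is meant among the compounds shown, and "the series" means these compounds.

Measured so far:
compound 1 `CSc1cnc2ccccc2c1[Se]CC#CCO` — 2.6 ug/mL
compound 2 `CCOC(=O)OCC#CCSc1c(SC)cnc2ccccc12` — 34.7 ug/mL

In a functional assay on P388 cells (Mus musculus) for antiproliferative activity, with a stated time of 72 h (a lower number here means a stronger inhibitor, a higher number a weaker inhibitor), compound 2 gives 34.7 ug/mL, the highest of the two numbers shown, while compound 1 gives 2.6 ug/mL, a gap well beyond the scatter. Compound 3 `CSc1cnc2ccccc2c1SCC#CCO` differs from compound 2 by hydrogen in place of ethoxycarbonyl on an oxygen on a saturated carbon. Within the data shown here, no step between two measured compounds is available, so the expectation rests on compound 1, which also carries the hydroxy group and gives 2.6 ug/mL. The expected step of a 6.9-fold lower number from compound 2 to compound 3 (0.84 log units; beyond the scatter) is therefore a large decrease in the number, beyond the scatter. Compound 3 is estimated at 5 ug/mL, expected between 1.5 ug/mL and 15 ug/mL.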

Compound 3, concentration for 50% inhibition: 3.1 ug/mL
Beside the measured number, compound 3's estimate is 1.6-fold (0.21 log units) above it; measured number inside the range.
By their numbers in this assay, from the lowest: compounds 1 and 3 (each within the scatter of the next); then compound 2.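

In this assay, hydrogen in place of ethoxycarbonyl on this oxygen gives an 11-fold lower number from compound 2 to compound 3 (1.05 log units; beyond the scatter), so the activity of this pair depends strongly on what the oxygen carries. Exchanging selenium for sulfur on the aromatic carbon gives a 1.2-fold higher number from compound 1 to compound 3 (0.08 log units; within the scatter), so compound 1 and compound 3 cannot be told apart in this assay. Nothing shown accounts for either step. On these data alone, it remains open whether a smaller acetyl or a methyl on this oxygen would stay close to hydrogen or to ethoxycarbonyl. As far as these compounds go, an amine in place of the hydroxy group also remains untested here.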